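Clearance of a cyano compound and its hydroxyethyl analogue

A few compounds are considered here, and "the series" means these few. Any claim that something is new, unique, unknown or untested is made for them only; others in the source may bear on it.

Compound 1 `CC(C)OC[C@H](Oc1ncnc2c1cnn2-c1ncccc1Cl)C(=O)Nc1ccc(F)cn1`: 130 mL/min/kg
Compound 2 `CC(C)OC[C@H](Oc1ncnc2c1cnn2-c1ncccc1Cl)C(=O)Nc1ccc(C#N)cn1`: 21 mL/min/kg
Compound 3 `N#Cc1ccc(NC(=O)[C@H](COCCO)Oc2ncnc3c2cnn3-c2ncccc2Cl)nc1`: not yet measured

In an ADME assay on the whole organism for pharmacokinetics, with Rattus norvegicus as the target (on this read-out higher numbers stand for fast clearance and lower numbers for slow clearance), compound 2 stands lowest of the two measured compounds, at 21 mL/min/kg. Compound 3 keeps the nitrile of compound 2 and changes one group: 2-hydroxyethyl in place of isopropyl on an oxygen on a saturated carbon. Within the data shown here, the only measured step, a 6.2-fold lower number from compound 1 to compound 2 (0.79 log units; beyond the scatter), is cyano in place of fluoro on an aromatic carbon. It shows that one change can move this read-out, but it is a different change at a different place. Among the measured compounds shown here, the data therefore hold no measured step for 2-hydroxyethyl in place of isopropyl, and they set no firm direction. The expected change is small, with the estimated step being a 1.3-fold lower number from compound 2 to compound 3 (0.12 log units; within the scatter). The estimate for compound 3 is 16 mL/min/kg, with an expected range of 6 mL/min/kg to 45 mL/min/kg.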

Compound 3, clearance: 13 mL/min/kg
Estimate against measurement, compound 3: 1.2-fold (0.09 log units) above; the measured number falls inside the stated range.
By their numbers in this assay, from the lowest: compounds 3 and 2 (each within the scatter of the next); then compound 1.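

In this assay, 2-hydroxyethyl in place of isopropyl on this oxygen gives a 1.6-fold lower number from compound 2 to compound 3 (0.21 log units; within the scatter), so the two compounds cannot be told apart on this read-out. Among these compounds, the earlier pair spoke only to the aromatic carbon that carries the nitrile, while this pair gives the first reading at the oxygen on the saturated carbon. There, a group with one hydrogen-bond donor and one hydrogen-bond acceptor enters with no step beyond the scatter, and no measurement at hand accounts for this result. On these data alone, whether an amine, a carboxylic acid or a longer chain on this oxygen would stand apart from compound 2 remains open. As far as these compounds go, it is also open whether 2-hydroxyethyl would give the same reading with fluoro on the aromatic carbon in place of the nitrile.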